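The source may hold more compounds than are shown below. What is called first, only, known or untested is meant among the compounds shown, and "the series" means these compounds.

Working notes on the series. Compound 1 `COC(=O)c1ccc(NCc2cncn2Cc2cccc([N+](=O)[O-])c2)cc1-c1ccccc1` is the one measured point. In a toxicity assay on NIH3T3 cells (Mus musculus) for cytotoxicity, read by resazurin assay (a higher number here means that more compound is needed for the effect, a lower number that less compound is needed), compound 1 gives > 10000 nM, which is a limit of the assay rather than a number, as the limit of > 10000 nM in this assay, at which 1 of the 2 values shown sits, records. Compound 2 `COC(=O)c1ccc(NCc2cncn2Cc2ccccc2OC)cc1-c1ccccc1` has no number in this assay at all; the entry for compound 2 reads "not determined" (no result reported). Compound 3 `COC(=O)c1ccc(NCc2cncn2Cc2ccccc2[N+](=O)[O-])cc1-c1ccccc1` differs from compound 2 by nitro in place of methoxy on an aromatic carbon. Among the measured compounds shown here, no measured step covers this change, so in this assay the step from compound 2 to compound 3 is expected to stay within the scatter, with no clear direction. For compound 3 in this assay the expected value is 10000 nM, with a range from 4000 nM to 30000 nM, and another limit is the likeliest outcome.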

Compound 3, half-maximal effective concentration: 10000 nM
Compound 3: middle estimate and measured number agree at the digits printed; measured number inside the range.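

In this assay, among the compounds shown here, compound 3 gives 10000 nM, the first actual number for this position, here with 2-nitrobenzyl on the shared core. With the nitro group moved, the change reads as a number no higher from compound 1 to compound 3 (the limit leaves the size open). The entry for compound 1 remains a limit of the assay, not a number: the limit of > 10000 nM in this assay, at which 1 of the 3 values shown sits.

Still open, as far as these compounds go, is whether moving the nitro group changes the value at all, since only a limit stands on one side of the step. Also open, from the compounds shown here alone, is how an amine or a carboxylic acid in place of nitro would read in this assay.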